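Swapping Dimethylamino for Methoxy on a Weakly Active Core

This account rests on a few compounds, and the source may have more. Where it says the series, first, only, none or still open, it means among the compounds named here.

Measured compounds:
- Compound 1, `COc1ncnc2c1c(-c1cccs1)cn2[C@@H]1O[C@H](CO)[C@@H](O)[C@H]1O`: in a functional assay on HepG2 cells (Homo sapiens) for antiproliferative activity, read by XTT assay, with a stated time of 72 h (a higher number here means a weaker inhibitor, a lower number a stronger inhibitor), compound 1 gives 13900 nM.
- Compound 2, `CN(C)c1ncnc2c1c(-c1cccs1)cn2[C@@H]1O[C@H](CO)[C@@H](O)[C@H]1O`: compound 2 reaches only the limit of this assay, > 20000 nM.
- Compound 3, `CN(C)c1ncnc2c1c(-c1cc3ccccc3o1)cn2[C@@H]1O[C@H](CO)[C@@H](O)[C@H]1O`: compound 3 also reaches only the limit, > 20000 nM.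

All three compounds are weak in this assay, and two of the three values are limits rather than numbers, (the limit of > 20000 nM in this assay, at which 2 of the 3 values shown sit). The change from compound 2 to compound 1 is methoxy in place of dimethylamino on an aromatic carbon. This gave an at least 1.4-fold lower number from compound 2 to compound 1 (0.15 log units; that floor lies within the scatter), so the two compounds cannot be told apart with confidence. The change from compound 2 to compound 3 is 1-benzofuran-2-yl in place of thiophen-2-yl on an aromatic carbon, which gave a step that the two limits leave unreadable from compound 2 to compound 3, since both ends sit at the limit.

Compound 4, `COc1ncnc2c1c(-c1cc3ccccc3o1)cn2[C@@H]1O[C@H](CO)[C@@H](O)[C@H]1O`, has not been measured. It differs from compound 3 by methoxy in place of dimethylamino on an aromatic carbon. The place description is word for word the same as for the step from compound 2 to compound 1, so this is the same change on a core that differs in the way given for the step from compound 2 to compound 3.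

Compound 1 gave 13900 nM. The measured step was an at least 1.4-fold lower number from compound 2 to compound 1 (0.15 log units; that floor lies within the scatter). On this basis the expected step is an at least 1.1-fold lower number from compound 3 to compound 4 (0.04 log units; that floor lies within the scatter), small and possibly hidden by the limit. Compound 4 is therefore expected to give about 18000 nM, estimated between 6000 nM and 50000 nM, with a fair chance that only a limit is reported.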

Compound 4, half-maximal inhibitory concentration: > 20000 nM
Compound 4 ended at the assay's limit (the forecaster's own chance of this, stated with the estimate: 50%); at least 1.1-fold (0.04 log units) between middle value and limit.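

In this assay compound 4 gives > 20000 nM, which is a limit of the assay and not a number. Compound 3 sits at that same limit, so the step between them cannot be read, and neither can any other step that has a limit at both ends; the swap of dimethylamino for methoxy therefore can be neither confirmed nor ruled out as carrying over from the core of compound 2 to the core of compound 3, because most of the series rests on limits rather than numbers: the limit of > 20000 nM in this assay, at which 3 of the 4 values shown sit. The other new step, which keeps methoxy and changes only the group on the other part of the core, is an at least 1.4-fold higher number from compound 1 to compound 4 (0.15 log units; that floor lies within the scatter) and so does not separate 1-benzofuran-2-yl from thiophen-2-yl with any confidence.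

The compounds shown leave open whether any group at the place next to the ring nitrogen can bring this core clearly inside the range of the assay, for example a primary amine or a longer chain such as butoxy. They also leave open whether a change at that place would behave alike on both cores once both ends of the step give real numbers.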